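Working notes on compounds 1 to 4

This account rests on a few compounds, and the source may have more. Where it says the series, first, only, none or still open, it means among the compounds named here.

Measured so far in a functional assay on MDA-MB-231 cells (Homo sapiens) for antiproliferative activity, read by MTT assay, with a stated time of 72 h; a lower number here means a stronger inhibitor, a higher number a weaker inhibitor:
- compound 1 `CCC(C)SSC(=S)N(CC)CC`: 6000 nM
- compound 2 `S=C(SSC1CCCCC1)N1CCCC1`: 4700 nM
- compound 3 `S=C(SSC(=S)N1CCCC1)N1CCCC1`: > 10000 nM, which is a limit of the assay and not a number

Among the two numbers given in this assay, compound 1 stands at the higher one, with compound 2 a short way beneath it; the gap lies within the usual scatter of such measurements, so no order between compound 1 and compound 2 can be read from these two values. Compound 3 sits at a limit, as noted (the limit of > 10000 nM in this assay, at which 1 of the 3 values shown sits); its value gives no number to compare against.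

Compound 4 `CCCCSSC(=S)N(CC)CC` has not yet been measured. It differs from compound 1 only at the sulfur: butyl in place of sec-butyl on a sulfur. The two compounds have the same atoms, joined differently. Going by the values given here, no step between measured compounds is available, so the effect of such a change is not known from these data.

The expectation for compound 4 is therefore a step of no size beyond the scatter, in no particular direction, from compound 1, written as no change at the digits printed from compound 1 to compound 4 (within the scatter). In this assay compound 4 is estimated at 6000 nM, with a range from 2500 nM to 14000 nM.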

Compound 4, half-maximal inhibitory concentration: 7400 nM
Estimate against measurement, compound 4: 1.2-fold (0.09 log units) below; measured number inside the range.
By their numbers in this assay, from the lowest: compounds 2, 1 and 4 (each within the scatter of the next). At a limit, above all of these: compound 3.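

Butyl in place of sec-butyl on a sulfur whose other neighbours are sulfur gives, in this assay, a 1.2-fold higher number from compound 1 to compound 4 (0.09 log units; within the scatter), and this is the first step in the series that can be read at all. At this position, then, rearranging the same four carbons from the sec-butyl to the butyl chain leaves the two compounds indistinguishable in this read-out, so branching of this chain, in this one pair, does not set them apart. Nothing in the data shown bears on why the two values sit so close.

From the compounds shown here alone, this is a single pair on a single core, so it says nothing about chains of another length or about other kinds of group at this sulfur: whether a longer chain such as octyl, a phenyl ring, or a chain ending in an amine or a carboxylic acid would move the number beyond the scatter stays open. Whether butyl in place of sec-butyl would give a similar step on the core of compound 2 also stays open, since no such pair is shown there.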